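The source may hold more compounds than are shown below. What is called first, only, known or untested is meant among the compounds shown, and "the series" means these compounds.

In a functional assay on U-251 cells (Homo sapiens) for antiproliferative activity (on this read-out lower numbers stand for stronger inhibition of growth and higher numbers for weaker inhibition of growth), compound 1 (`Cc1ccnc2nc(-c3cccc(Cl)c3)cc(O)c12`) gives 52.5 nM and compound 3 (`Cc1cc(C)c2c(O)cc(-c3cccc4ccccc34)nc2n1`) gives 372 nM, so compound 1 holds the lower of the two exact numbers. Compound 2 (`Cc1ccnc2nc(-c3cccc4ccccc34)cc(O)c12`) reads < 10 nM, which is a limit of the assay and not an exact number.

Compound 4 (`Cc1cc(C)c2c(O)cc(-c3cccc(Cl)c3)nc2n1`) departs from compound 1 by a single change, methyl in place of hydrogen on an aromatic carbon, next to the ring nitrogen (methyl in place of hydrogen on an aromatic carbon). Among the measured compounds shown here, one measured step bears on this change: an at least 37-fold higher number from compound 2 to compound 3 (1.57 log units; beyond the scatter), which makes the same replacement while carrying a different substituent elsewhere on the shared core. That step is large and lies beyond the scatter, and it points toward weaker inhibition of growth. For the measured compounds named here, it is only one pair, however, so its size cannot be carried over with confidence to the chlorinated series.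

A large rise in this assay is therefore expected, and a slightly smaller one than that single pair might suggest. The estimated change is a 29-fold higher number from compound 1 to compound 4 (1.46 log units; beyond the scatter), again toward weaker inhibition. For compound 4 the expected value is 1500 nM, with an estimated range from 300 nM to 6000 nM.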

Compound 4, concentration for 50% growth inhibition: 295 nM
The estimate for compound 4 lay 5.1-fold (0.71 log units) above the measured number, outside the stated range (below it).
By their numbers in this assay, from the lowest: compound 1; then compounds 4 and 3 (each within the scatter of the next). At a limit, below all of these: compound 2.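

In this assay, methyl in place of hydrogen on this aromatic carbon, next to the ring nitrogen, again goes with weaker inhibition of growth, now on the core of compound 1, with a 5.6-fold higher number from compound 1 to compound 4 (0.75 log units; beyond the scatter). The direction seen in the single earlier pair thus recurs on a second core, but the size of the step does not carry over and differs with what the core carries elsewhere: the same change on two cores in this assay, an at least 37-fold higher number (1.57 log units; beyond the scatter) from compound 2 to compound 3 and a 5.6-fold higher number (0.75 log units; beyond the scatter) from compound 1 to compound 4, at least 6.6-fold (0.82 log units) apart, beyond the scatter of two such steps The first of these steps rests on compound 2, whose reading is a limit and not an exact number: the limit of < 10 nM in this assay, at which 1 of the 4 values shown sits.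

The compounds shown have only hydrogen or methyl at this place, so it stays open how an ethyl group, a methoxy group or an amine there would read in this assay, and whether any group can be placed there without weakening inhibition of growth. Two pairs also cannot show how the size of the step would vary with other groups elsewhere on the shared core, such as a fluorine atom in place of the chlorine of compound 1.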